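Working notes on a side-chain change in one amide series

The compounds below may be only part of what the source reports. "The series", "measured", "known", "first", "only" and "open" are said of these compounds alone.

Measured so far:
compound 1 `Cn1nc(Cc2nnc(SCCCCCCCC(=O)Nc3ccc(Cl)cc3Cl)n2CCC=O)c2ccccc2c1=O`: 5500 nM
compound 2 `Cn1nc(Cc2nnc(SCC(=O)Nc3ccc(Cl)cc3Cl)n2CCCO)c2ccccc2c1=O`: > 30000 nM

In an assay on 32D cells for inhibition of interleukin-15 (Mus musculus), read by resazurin assay, with stated times of 30 min and 2.5 days, in the presence of a further agent that is not named here (on this read-out higher numbers stand for weaker inhibition and lower numbers for stronger inhibition), compound 1 gives 5500 nM. Compound 2 gives > 30000 nM in this assay, and that is a limit of the assay rather than a number. For the measured compounds named here, compound 1 therefore carries the only number in the set; the other entry is a limit, as noted in the limit of > 30000 nM in this assay, at which 1 of the 2 values shown sits. Going by the values given here, no step between two measured compounds that differ in one place exists, so nothing here tells how much a single change on the side chain moves this read-out.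

Compound 3 `Cn1nc(Cc2nnc(SCCCCCCCC(=O)Nc3ccc(Cl)cc3Cl)n2CCCO[Si](C)(C)C(C)(C)C)c2ccccc2c1=O` is not yet measured. It differs from compound 1 by a group of 9 heavy atoms (7 carbon, 1 oxygen, 1 silicon; no ring) in place of a group of 2 heavy atoms (1 carbon, 1 oxygen; no ring), on a saturated chain carbon, two bonds along the chain from an aromatic nitrogen. Among the compounds with values here, with no measured step to lean on, a change of modest size is expected, more likely toward weaker inhibition than stronger, and possibly no change beyond the scatter. In this assay the expected step is a 1.6-fold higher number from compound 1 to compound 3 (0.21 log units; within the scatter). Compound 3 is accordingly estimated at 9000 nM, with a range from 2500 nM to 30000 nM.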

Compound 3, half-maximal inhibitory concentration: > 30000 nM
Compound 3: only a limit was reported (the forecaster's own chance of this, stated with the estimate: 30%); middle value at least 3.3-fold (0.52 log units) away from the limit.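

In this assay the series now has its first step between two compounds that differ in one place, an at least 5.4-fold higher number from compound 1 to compound 3 (0.73 log units; beyond the scatter), so the read-out does respond to a change on this saturated chain carbon, two bonds along the chain from an aromatic nitrogen. The two groups have the same hydrogen-bond donor and acceptor counts and differ in heavy atoms, and the step lies beyond the scatter, but compound 3 gives > 30000 nM, which is a limit of the assay and not a number, so the step gives only the least size of the change. With compound 3, limits now outnumber measured values in the set: the limit of > 30000 nM in this assay, at which 2 of the 3 values shown sit.

The compounds shown leave open how much of the step goes with the number of heavy atoms and how much with the silicon-bearing group itself. A hydroxyl, an amine or a carboxylic acid in place of the formyl on the core and chain of compound 1 would test this, whereas compound 2 differs from compound 1 in more than one place and cannot.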